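The source may report more compounds than this note shows. Statements on the series, on what has been measured and on what is new or still open speak of the compounds shown alone.

Working notes on the series.

Compound 1 `O=C(O)Cc1nn(Cc2nc3c(Cl)cccc3s2)c(=O)c2ccccc12` gives 63% in an in vivo functional assay on the whole organism for inhibition of sorbitol dehydrogenase (Rattus norvegicus), at a dose of 10 mg/kg by the oral route; on this read-out lower numbers stand for less inhibition and higher numbers for more inhibition at the one dose given (going by the name of the read-out). Among the measured compounds shown here, compound 2 `O=C(O)Cc1nn(Cc2nc3c(C(F)(F)F)cccc3s2)c(=O)c2ccccc12` gives 61% in this assay; the single step of a number 2 percentage points lower from compound 1 to compound 2 (within the scatter) is trifluoromethyl in place of chloro on an aromatic carbon. Compound 3 `O=C(O)Cc1nn(Cc2nc3cccc(Cl)c3s2)c(=O)c2ccccc12` gives 52% in this assay, the lowest of the three numbers recorded, with the gap to compound 2 within the scatter and only the gap to compound 1 beyond it.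

Compound 4 `O=C(O)Cc1nn(Cc2nc3cccc(C(F)(F)F)c3s2)c(=O)c2ccccc12` is not yet measured. It differs from compound 3 by trifluoromethyl in place of chloro on an aromatic carbon. For the measured compounds named here, the one measured step that bears on this exchange is a number 2 percentage points lower from compound 1 to compound 2 (within the scatter), the same replacement of chloro by trifluoromethyl on an aromatic carbon of the shared core, and it stayed within the scatter. On that basis no step beyond the scatter is expected in this assay for compound 4 in either direction, so the expected step is a number 2 percentage points lower from compound 3 to compound 4 (within the scatter). Compound 4 is therefore estimated at 50%, within a range of 38% to 62%.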

Compound 4, a percentage reported as inhibition, in the whole organism at one dose (the size of the read-out at that dose, not a potency): 80%
Beside the measured number, compound 4's estimate is 30 percentage points below it; the whole stated range lies below it.
By their numbers in this assay, from the lowest: compounds 3, 2 and 1 (each within the scatter of the next, the first and the last beyond it); then compound 4.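

In this assay, trifluoromethyl in place of chloro on an aromatic carbon is not a neutral exchange at this position, ortho to a fused ring and meta to a fused ring: the step is a number 28 percentage points higher from compound 3 to compound 4 (beyond the scatter). The earlier pair alone gave no sign of such a gain, so the exchange cannot be carried from one core to the other as a fixed increment. The outcome of the same change differs with the core that carries it: the same change on two cores in this assay, a number 2 percentage points lower (within the scatter) from compound 1 to compound 2 and a number 28 percentage points higher (beyond the scatter) from compound 3 to compound 4, 30 percentage points apart, beyond the scatter of two such steps

Going by these compounds, whether the gain is particular to trifluoromethyl at this place, or would also appear with bromo, methyl or a nitrile on the same aromatic carbon, remains open. These single-dose numbers give no potency, and they give no reason for the difference between the two cores.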